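The source may hold more compounds than are shown below. What is called first, only, known or untested is meant among the compounds shown, and "the series" means these compounds.

Series notes, lipophilicity. The read-out throughout is a physicochemical assay for lipophilicity, using the shake flask method, measured as octanol-water partition, with a stated time of 24 h, at 25 degrees C; a lower number here means a more polar compound, a higher number a more lipophilic compound. Compound 1 `Fc1ccccc1CN(Cc1nnn[nH]1)c1ccccc1` gives 1.28. Among the compounds with values here, compound 2 `CCCCCCN(Cc1nnn[nH]1)c1ccccc1` gives 2.18, and the change a number 0.90 log units higher from compound 1 to compound 2 (beyond the scatter) is the only single-point step so far measured. Compound 3 `Cc1ccc(N(Cc2nnn[nH]2)Cc2ccc(Cl)cc2Cl)cc1` gives 1.99, which places it second highest of the three values: its gap to compound 2 lies within the scatter, while its gap to compound 1 lies beyond it.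

Compound 4 `Clc1ccc(CN(Cc2nnn[nH]2)c2ccccc2)c(Cl)c1` differs from compound 3 in one place: hydrogen in place of methyl on an aromatic carbon, the methyl leaving an aromatic carbon of a six-membered aromatic ring of carbon only, para to a large group, so that 4-methylphenyl becomes phenyl. Within the data shown here, no measured step covers a methyl-to-hydrogen change on an aromatic ring; the step from compound 1 to compound 2 concerns a different part of the molecule and gives no direct guidance. Loss of one carbon with no change in donors, acceptors or charge is expected to give a small decrease in this assay, likely close to the edge of the scatter.

On that basis compound 4 is estimated at 1.5, in the range 1.1 to 1.9, corresponding to an expected step of a number 0.49 log units lower from compound 3 to compound 4 (beyond the scatter).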

Compound 4, partition coefficient: 1.67
Compound 4: middle estimate off by 0.17 log units, on the low side; the measured number falls inside the stated range.
By their numbers in this assay, from the lowest: compound 1; then compound 4; then compounds 3 and 2 (each within the scatter of the next).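

Within the data shown here, removing the methyl from an aromatic carbon para to a large group, so that 4-methylphenyl becomes phenyl, gives a number 0.32 log units lower from compound 3 to compound 4 (beyond the scatter) in this assay, the first reading of any change at this position. Among these compounds, only one carbon leaves, with no hydrogen-bond donors or acceptors and no net charge involved, yet the step is still beyond the scatter, so this position cannot be treated as indifferent in this read-out, at least for this pair; the only earlier step, a number 0.90 log units higher from compound 1 to compound 2 (beyond the scatter), belongs to a different place and says nothing on this point. Nothing measured here accounts for the size of the step.

A single pair cannot show whether the same step would recur with a different group on the shared nitrogen, for instance with the chain of compound 2 in place of the substituted benzyl-type group kept constant in this pair. The compounds shown also leave open how an amine, a carboxylic acid, a methoxy group or a longer chain at this same aromatic carbon would compare with the methyl and the hydrogen.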